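Swapping the ether tail on a translocator protein ligand

This account rests on a few compounds, and the source may have more. Where it says the series, first, only, none or still open, it means among the compounds named here.

Compound 1 `CC(=O)N(Cc1ccccc1)c1cc(C)cc(C)c1`: 1260 nM
Compound 2 `CC(=O)N(Cc1ccc(OCCF)cc1)c1cc(C)cc(C)c1`: 3930 nM

Both measured compounds share the same core and were tested in an assay on HEK293 cells for displacement of a labelled ligand from Translocator protein (Homo sapiens), read by scintillation counting, with a stated time of 90 min; on this read-out higher numbers stand for weaker inhibition and lower numbers for stronger inhibition. Compound 1 gives 1260 nM, while compound 2 gives 3930 nM. The sole difference between them, 2-fluoroethoxy in place of hydrogen on an aromatic carbon, produced a 3.1-fold higher number from compound 1 to compound 2 (0.49 log units; beyond the scatter). Compound 2 therefore holds the higher of the two numbers shown, with compound 1 as its only neighbour.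

Compound 3 `CC(=O)N(Cc1ccc(OC(C)C)cc1)c1cc(C)cc(C)c1` is the next member. Relative to compound 2 the change is isopropyl in place of 2-fluoroethyl on an oxygen on an aromatic ring. Among the compounds with values here, no measured step bears directly on this exchange: the one step known trades a hydrogen for the whole 2-fluoroethoxy group, not one ether tail for another. With the ether oxygen and a tail of the same atom count kept in place, the expectation is no step beyond the scatter, so the estimated change from compound 2 to compound 3 is a 1.1-fold lower number from compound 2 to compound 3 (0.05 log units; within the scatter). Compound 3 is accordingly estimated at 3500 nM, within a range from 1200 nM to 10000 nM.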

Compound 3, inhibition constant: 3150 nM
Compound 3: the middle estimate sits 1.1-fold (0.05 log units) above what was measured; the measured number falls inside the stated range.
By their numbers in this assay, from the lowest: compound 1; then compounds 3 and 2 (each within the scatter of the next).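

In this assay the exchange of one ether tail for the other gives a 1.2-fold lower number from compound 2 to compound 3 (0.10 log units; within the scatter), so on this oxygen the isopropyl and 2-fluoroethyl tails cannot be told apart, and the fluorine is not needed to hold the number where it stands. Putting isopropoxy in place of hydrogen on the aromatic carbon gives a 2.5-fold higher number from compound 1 to compound 3 (0.40 log units; beyond the scatter), which runs in the same direction as a 3.1-fold higher number from compound 1 to compound 2 (0.49 log units; beyond the scatter), so among these compounds the weaker inhibition is not tied to one particular ether tail. The data shown offer no measurement that would explain either step.

From the compounds shown here alone, what remains open is whether the weaker inhibition comes from the ether oxygen itself or from the tail attached to it, a question that a small methoxy group or a hydroxyl group on the same aromatic carbon would address. A longer chain, or an amine at the end of the tail, could also show whether the number stays put with tails that differ more from these two.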